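A methyl for a fluorine on the pendant phenyl

The source may hold more compounds than are shown below. What is called first, only, known or untested is meant among the compounds shown, and "the series" means these compounds.

Measured so far in a functional assay on HeLa cells (Homo sapiens) for inhibition, read by CCK-8 assay, with a stated time of 48 h; on this read-out higher numbers stand for weaker inhibition and lower numbers for stronger inhibition:
Compound 1, `COc1cc(-c2ccnc3cc(-c4ccc(C(C)=O)cc4)nn23)cc(OC)c1OC`, gives 1810 nM.
Compound 2, `COc1cc(-c2ccnc3cc(-c4ccc5cnn(C)c5c4)nn23)cc(OC)c1OC`, gives 97 nM.
Compound 3, `COc1cc(-c2ccnc3cc(-c4ccc(F)cc4)nn23)cc(OC)c1OC`, gives 5840 nM.

Compound 3 has the highest number of the three, meaning the weakest inhibition: there is a 3.2-fold higher number from compound 1 to compound 3 (0.51 log units; beyond the scatter), and a 60-fold higher number from compound 2 to compound 3 (1.78 log units; beyond the scatter).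

Compound 4, `COc1cc(-c2ccnc3cc(-c4cccc(C)c4)nn23)cc(OC)c1OC`, is not yet measured. It differs from compound 3 in one place: 3-methylphenyl in place of 4-fluorophenyl on an aromatic carbon. Among the measured compounds shown here, one measured step bears on this most directly, because a 3.2-fold higher number from compound 1 to compound 3 (0.51 log units; beyond the scatter) also exchanges one small group on the same pendant phenyl and was modest. The step of a 60-fold higher number from compound 2 to compound 3 (1.78 log units; beyond the scatter) replaced the whole phenyl with a fused ring and was large, but compound 4 keeps a plain phenyl, so it speaks less to this change. For the measured compounds named here, no measured step places a methyl anywhere. The expectation for compound 4 is therefore a small change, a 1.5-fold lower number from compound 3 to compound 4 (0.16 log units; within the scatter), likely not clearly beyond the scatter. Compound 4 is estimated at 4000 nM, within 1500 nM to 12000 nM.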

Compound 4, half-maximal inhibitory concentration: 4230 nM
Estimate against measurement, compound 4: 1.1-fold (0.02 log units) below; the range from low to high includes it.
By their numbers in this assay, from the lowest: compound 2; then compound 1; then compounds 4 and 3 (each within the scatter of the next).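

In this assay, 3-methylphenyl in place of 4-fluorophenyl gives a 1.4-fold lower number from compound 3 to compound 4 (0.14 log units; within the scatter) and leaves the two compounds indistinguishable, the first sign that two differently substituted plain phenyls can read alike at this aromatic carbon. The 4-acetylphenyl of compound 1 is still set apart, with a 2.3-fold higher number from compound 1 to compound 4 (0.37 log units; beyond the scatter) in this comparison. The 1-methyl-1H-indazol-6-yl group of compound 2 stands much further off, with a 44-fold higher number from compound 2 to compound 4 (1.64 log units; beyond the scatter) as the step, and among these four compounds it alone gives a number this low, though nothing measured here offers a reason for these differences.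

Compound 3 and compound 4 differ in both the substituent and its place on the phenyl, and these compounds do not separate the two. On these data alone, how an amine or a carboxylic acid on the phenyl would read remains open.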